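The compounds below may be only part of what the source reports. "The series", "measured", "known", "first", "only" and "open" are said of these compounds alone.

Compound 1 `COc1ccc(C2=NN(C3=NC(=O)/C(=C4\C(=O)Nc5ccc(Br)cc54)S3)C(c3ccc(Cl)cc3)C2)cc1`, compound 2 `COc1ccc(C2=NN(C3=NC(=O)/C(=C4\C(=O)Nc5ccc(Cl)cc54)S3)C(c3ccc(Cl)cc3)C2)cc1` and compound 3 `CN(C)c1ccc(C2CC(c3ccccc3)=NN2C2=NC(=O)/C(=C3\C(=O)Nc4ccc(Br)cc43)S2)cc1` have all been tested in a functional assay on cells (Cancer cell lines, Homo sapiens) for cytotoxicity, read by sulforhodamine B assay, with a stated time of 48 h; on this read-out lower numbers stand for stronger inhibition of growth and higher numbers for weaker inhibition of growth. Compound 1 gives 120 nM, compound 2 gives 190 nM and compound 3 gives 210 nM. The three numbers lie within the usual scatter of one another, so none of the three can be set apart from the others on this read-out. Compound 1 and compound 2 differ in a single place: chloro in place of bromo on an aromatic carbon. This change made a 1.6-fold higher number from compound 1 to compound 2 (0.20 log units; within the scatter). Compound 3 is built on a different core from compound 1; how the two cores differ is not broken down here. Compound 4 `CN(C)c1ccc(C2CC(c3ccccc3)=NN2C2=NC(=O)/C(=C3\C(=O)Nc4ccc(Cl)cc43)S2)cc1` has not yet been measured. It differs from compound 3 in one place: chloro in place of bromo on an aromatic carbon. This is the same change as the one from compound 1 to compound 2, at the same place, and it occurs twice among these compounds. Because the earlier step, a 1.6-fold higher number from compound 1 to compound 2 (0.20 log units; within the scatter), stayed within the scatter, a step of similar size is expected here, and compound 4 is expected to make a 1.4-fold higher number from compound 3 to compound 4 (0.15 log units; within the scatter). Compound 4 is therefore estimated at 300 nM, between 150 nM and 600 nM.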

Compound 4, concentration for 50% growth inhibition: 190 nM
Compound 4: the middle estimate sits 1.6-fold (0.20 log units) above what was measured; low and high end bracket the measured number.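

On the second core, chloro in place of bromo made a 1.1-fold lower number from compound 3 to compound 4 (0.04 log units; within the scatter) in this assay. Set beside the step on the first core, this one cannot be told apart from it: the same change on two cores in this assay, a 1.6-fold higher number (0.20 log units; within the scatter) from compound 1 to compound 2 and a 1.1-fold lower number (0.04 log units; within the scatter) from compound 3 to compound 4, 1.8-fold (0.24 log units) apart, within the scatter of two such steps So on both cores in this series, bromo and chloro on this aromatic carbon can be exchanged without a change that this read-out can detect, and the result carries from one core to the other; this does not show that the two groups are truly equal, and two pairs in a single assay say nothing about how the swap would behave on a third core.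

The compounds shown leave open what other groups on this same aromatic carbon would do, such as fluoro, a nitrile or a carboxylic acid, and whether any of them would move the number by more than the scatter. They also leave open whether bromo and chloro would stay interchangeable on a read-out other than growth inhibition.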